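A few compounds are considered here, and "the series" means these few. Any claim that something is new, unique, unknown or untested is made for them only; others in the source may bear on it.

Compound 1 `COc1cc(-c2cnn3cc(OC)c(C(C)C)nc23)ccn1` gives 3800 nM in an assay on isolated protein for inhibition of activin receptor type-2A (Homo sapiens), read by 33P incorporation, with a stated time of 20 min, in the presence of a further agent that is not named here; on this read-out higher numbers stand for weaker inhibition and lower numbers for stronger inhibition. Compound 2 `COc1cc(-c2cnn3cc(OC)c(-c4cc(C)no4)nc23)ccn1` gives 3000 nM in this assay. Compound 3 `COc1cc(-c2cnn3cc(OC)c([C@@H]4COC(C)(C)C4)nc23)ccn1` gives 5300 nM in this assay.

Compound 3 has the highest of the three numbers, but neither gap separates it from the others: a 1.4-fold higher number from compound 1 to compound 3 (0.14 log units; within the scatter) and a 1.8-fold higher number from compound 2 to compound 3 (0.25 log units; within the scatter), both within the scatter, so the three compounds cannot be ordered on these data.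

Compound 4 `COc1cc(-c2cnn3cc(OC)c([C@H]4COC(C)(C)C4)nc23)ccn1` is the unmeasured partner of compound 3. The change is the two compounds have the same atoms and bonds and differ only in configuration as drawn: 1 of 1 stereo elements differ; a stereocentre at a saturated ring carbon is drawn R in compound 3 and S in compound 4. Among the compounds with values here, none of the measured steps concerns a change of configuration; the steps from compound 1 and compound 2 to compound 3 replace one whole group by another and still stay within the scatter, so they offer no guide to the size or direction of a step that keeps every atom and bond and alters only the drawn configuration. Within the data shown here, with no step of this kind among the measured compounds, the account expects for compound 4 a number close to that of compound 3, with a wide range, and a step of a 1.1-fold lower number from compound 3 to compound 4 (0.03 log units; within the scatter) that is expected to fall within the scatter. The estimate for compound 4 in this assay is 5000 nM, with a range from 1800 nM to 14000 nM.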

Compound 4, half-maximal inhibitory concentration: 4100 nM
Compound 4: the middle estimate sits 1.2-fold (0.09 log units) above what was measured; the measured number falls inside the stated range.
By their numbers in this assay, from the lowest: compounds 2, 1, 4 and 3 (each within the scatter of the next).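

Changing only the drawn configuration at the saturated ring carbon leaves this assay unable to separate the two forms (a 1.3-fold lower number from compound 3 to compound 4 (0.11 log units; within the scatter)). The form drawn S also stays close to the compounds carrying the other two groups at this position (a 1.4-fold higher number from compound 2 to compound 4 (0.14 log units; within the scatter); a 1.1-fold higher number from compound 1 to compound 4 (0.03 log units; within the scatter)), so neither form stands apart from them. Within the data shown here, this pair gives the set its only reading of configuration alone, since no other structural change accompanies it: the fact that compounds 3 and 4 differ only in the configuration as drawn.

The compounds shown leave open whether an amine or a carboxylic acid in place of isopropyl at this position would give a step beyond the scatter. They also leave open whether configuration would count for more on a ring carrying a hydroxyl group.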